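A few compounds are considered here, and "the series" means these few. Any claim that something is new, unique, unknown or untested is made for them only; others in the source may bear on it.

Measured compounds in a functional assay on MGC-803 cells (Homo sapiens) for cytotoxicity, read by MTT assay, with a stated time of 48 h; a higher number here means a weaker inhibitor, a lower number a stronger inhibitor:

- compound 1, `CC1=NN(C(=O)COc2ccc(Cl)cc2)C(c2cc(Br)ccc2O)C1`: compound 1 gives 23600 nM
- compound 2, `CC(=O)Oc1ccccc1C1CC(C)=NN1C(=O)CN1CCC(O)CC1`: compound 2 gives 3510 nM
- compound 3, `Cc1ccc(C(=O)N2N=C(c3cc4ccccc4oc3=O)CC2c2ccccc2)cc1`: compound 3 gives 31300 nM

Compound 3 sits at the high end of the three numbers. Compound 1 lies close to it, within the usual scatter, so no order between compound 3 and compound 1 can be read from these two values. Compound 2 is the one that stands apart: its number is well below that of compound 3, beyond the scatter, and compound 2 is built on a different core with a different acyl group on the ring nitrogen, so the gap cannot be tied to any single change.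

Compound 4, `Cc1ccc(S(=O)(=O)N2N=C(c3cc4ccccc4oc3=O)CC2c2ccccc2)cc1`, is the next member. Relative to compound 3 the change is (4-methylphenyl)sulfonyl in place of (4-methylphenyl)carbonyl on an amine nitrogen in a ring. Within the data shown here, no pair among the measured compounds differs in only this place, so there is no measured step to lean on for the size or direction of the effect. With nothing in this assay pointing either way, the working expectation is that the step from compound 3 to compound 4 stays within the scatter, neither clearly up nor down, and the estimated step is a 1.0-fold lower number from compound 3 to compound 4 (0.02 log units; within the scatter).

Compound 4 is therefore expected to give about 30000 nM in this assay, with a range from 9000 nM to 100000 nM.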

Compound 4, half-maximal inhibitory concentration: 50200 nM
Compound 4: middle estimate off by 1.7-fold (0.22 log units), on the low side; low and high end bracket the measured number.
By their numbers in this assay, from the lowest: compound 2; then compounds 1, 3 and 4 (each within the scatter of the next, the first and the last beyond it).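

In this assay, among these compounds, the exchange of (4-methylphenyl)carbonyl for (4-methylphenyl)sulfonyl on an amine nitrogen in a ring gives the first measured one-place step (a 1.6-fold higher number from compound 3 to compound 4 (0.21 log units; within the scatter)), and this step lies within the scatter, so the two linking groups cannot be told apart here. The 4-methylphenyl ring and the shared core stay the same across this pair, which ties the comparison to the carbonyl-to-sulfonyl exchange alone and shows that, with this ring attached, the exchange does not clearly separate the two compounds in this cytotoxicity read-out. No measured property of either group is available to bear on this step.

As far as these compounds go, it remains open whether the same holds with a different group on the sulfonyl or carbonyl, such as a short methyl group, a longer alkyl chain, or a phenyl ring carrying a methoxy group or an amine in place of the methyl group. Among the compounds shown here, no one-place step connects this pair to compound 2 (3510 nM), so what separates that compound from the rest also stays unresolved.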